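This account rests on a few compounds, and the source may have more. Where it says the series, first, only, none or still open, it means among the compounds named here.

Compound 1 `Cc1cc(NC(=O)Cn2cc(-c3ccc(C#N)cc3)nn2)no1` gives 9320 nM. Compound 2 `Nc1cccc(-c2cn(CC(=O)Nc3nc4ccccc4s3)nn2)c1` gives 1110 nM. Compound 3 `O=C(Cn1cc(-c2ccc([N+](=O)[O-])cc2)nn1)Nc1nc2ccccc2s1` gives 3280 nM.

In a functional assay on BMDM cells (Mus musculus, strain C57BL/6) for inhibition, with a stated time of 2 days (a lower number here means a stronger inhibitor, a higher number a weaker inhibitor), compound 3 stands second highest of the three numbers: compound 2 gives a lower number, and the step of a 3.0-fold higher number from compound 2 to compound 3 (0.47 log units; beyond the scatter) lies beyond the scatter, while compound 1 gives a higher number still. Compound 4 `Cc1cc(NC(=O)Cn2cc(-c3ccc([N+](=O)[O-])cc3)nn2)no1` differs from compound 3 in one place: 5-methyl-1,2-oxazol-3-yl in place of 1,3-benzothiazol-2-yl on an amide-type nitrogen. Among the compounds with values here, no measured pair differs in just this way. Within the data shown here, the one measured step, a 3.0-fold higher number from compound 2 to compound 3 (0.47 log units; beyond the scatter), concerns a different part of the molecule and does not bear directly on this change. What the numbers do show is that the 5-methyl-1,2-oxazol-3-yl group that compound 4 gains is carried by compound 1, which gives 9320 nM, the highest of the three, whereas both compounds carrying the 1,3-benzothiazol-2-yl group give lower numbers. On that slender basis a higher number is expected for compound 4, with the step of a 2.7-fold higher number from compound 3 to compound 4 (0.44 log units; beyond the scatter) expected to reach beyond the scatter, though with wide uncertainty. Compound 4 is therefore estimated at 9000 nM, within a range from 3000 nM to 30000 nM.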

Compound 4, half-maximal inhibitory concentration: 1220 nM
Compound 4: middle estimate off by 7.4-fold (0.87 log units), on the high side; measured number outside the range, below it.
By their numbers in this assay, from the lowest: compounds 2 and 4 (each within the scatter of the next); then compound 3; then compound 1.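

In this assay, within the data shown here, the step of a 2.7-fold lower number from compound 3 to compound 4 (0.43 log units; beyond the scatter) gives the first direct reading at the amide-type nitrogen: with the 4-nitrophenyl part held constant, 5-methyl-1,2-oxazol-3-yl gives a stronger inhibitor than the larger 1,3-benzothiazol-2-yl. The step of a 7.6-fold lower number from compound 1 to compound 4 (0.88 log units; beyond the scatter) keeps 5-methyl-1,2-oxazol-3-yl in place and changes only cyano to nitro on an aromatic carbon, so the high number of compound 1 cannot be read as a fixed penalty of that group. No measurement here explains either step.

As far as these compounds go, only the nitro-bearing pair tests this exchange, so it remains open whether the same direction holds with cyano or 3-aminophenyl elsewhere in the molecule. From the compounds shown here alone, how a plain phenyl group on the amide-type nitrogen, or a carboxylic acid in place of nitro, would behave also remains open.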